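The compounds below may be only part of what the source reports. "The series", "measured", "known", "first", "only" and "open" are said of these compounds alone.

Working notes on the series. In an ADME assay on HaCaT cells (Homo sapiens) for inhibition, read by sulforhodamine B assay, with a stated time of 48 h (a higher number here means a weaker inhibitor of growth, a lower number a stronger inhibitor of growth), compound 1 `CCOC(=O)c1nn(-c2ccccc2)c(-c2ccc(F)cc2)c1CNC(C)(C)C` gives 74500 nM; 32900 nM (2 entries). Compound 2 `CCOC(=O)c1nn(-c2ccccc2)c(-c2ccc(Br)cc2)c1CNC(C)(C)C` gives 61700 nM; > 509000 nM (2 entries). Compound 3 `CC(C)(C)NCc1c(C(=O)O)nn(-c2ccccc2)c1-c1ccc(F)cc1` has no firm number in this assay: compound 3 gives > 680000 nM, which is a limit of the assay, and its two further entries carry no single number either.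

Compound 4 `CC(C)(C)NCc1c(C(=O)O)nn(-c2ccccc2)c1-c1ccc(Br)cc1` follows from compound 3 with one change, bromo in place of fluoro on an aromatic carbon, para to a large group (bromo in place of fluoro on an aromatic carbon). The same difference reads 4-fluorophenyl to 4-bromophenyl.

For the measured compounds named here, no measured step gives a direct size for this change, so the expectation stays cautious. No step beyond the usual scatter is expected in this assay, in either direction, since compound 3 shows only the limit > 680000 nM. The estimated step of an at least 1.3-fold lower number from compound 3 to compound 4 (0.13 log units; that floor lies within the scatter) is therefore expected to remain small. A report of only a limit is also expected to be the likeliest outcome. For compound 4 the estimate is 500000 nM, with an expected range of 150000 nM to 1000000 nM.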

Compound 4, concentration for 50% growth inhibition: 366000 nM
Compound 4: the middle estimate sits 1.4-fold (0.14 log units) above what was measured, within the range that was stated.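

For the compounds shown here, compound 4 gives the first firm number for a carboxylic acid of this series in this assay, and the change of bromo in place of fluoro on an aromatic carbon, para to a large group, reads as an at least 1.8-fold lower number from compound 3 to compound 4 (0.26 log units; that floor lies within the scatter). Going by these compounds, compound 3 stands only at a limit, so the step is known as a floor and its full size stays unknown: the limit of > 680000 nM in this assay, at which 1 of the 4 values shown sits. Going by these compounds alone, the same change on the ethyl ester, from compound 1 to compound 2, gives no step that can be read, since compound 2 has no single number: the several entries of compound 2 in this assay, 61700 nM; > 509000 nM (2 entries).

The compounds shown leave open how a chloro or a methoxy group in the same place would read in this assay, and whether the firm number of compound 4 belongs to bromo alone or would also appear with a larger halogen such as iodo. They also leave open how an amide in place of the carboxylic acid would read with the 4-bromophenyl group kept, and whether the bromo change would then carry a step of measurable size.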